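Ethyl in Place of Methoxy, Carried to Compound 4

The compounds below may be only part of what the source reports. "The series", "measured", "known", "first", "only" and "open" are said of these compounds alone.

Compound 1, `COc1ccc(CN2CCCNC2=S)cc1`: 6100 nM
Compound 2, `CCc1ccc(CN2CCCNC2=S)cc1`: 1300 nM
Compound 3, `COc1ccc(CN2CCCNC2=O)cc1`: only a limit, > 10000 nM

Three compounds were measured in a functional assay on B16 cells (Mus musculus) for inhibition, with a stated time of 72 h; on this read-out lower numbers stand for stronger inhibition and higher numbers for weaker inhibition. Compound 1 gives 6100 nM in this assay. Compound 2, in this assay, gives 1300 nM. The two differ in one place, (ethyl in place of methoxy on an aromatic carbon), and that change gave a 4.7-fold lower number from compound 1 to compound 2 (0.67 log units; beyond the scatter). Compound 3 in this assay gives only a limit of the assay, > 10000 nM, which is the limit of > 10000 nM in this assay, at which 1 of the 3 values shown sits. How the core of compound 3 differs from the core of compound 1 is not broken down here.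

Compound 4, `CCc1ccc(CN2CCCNC2=O)cc1`, has not yet been measured. It differs from compound 3 by ethyl in place of methoxy on an aromatic carbon. The place is the same, word for word, as the place of the change from compound 1 to compound 2, so this is the same change carried to the second core. Among the measured compounds shown here, because compound 3 sits at > 10000 nM, no numerical step can be drawn from it, and any expectation for compound 4 has to borrow from the first pair. Resting on a 4.7-fold lower number from compound 1 to compound 2 (0.67 log units; beyond the scatter), the step for compound 4 is expected to be about an at least 2.0-fold lower number from compound 3 to compound 4 (0.30 log units; that floor lies within the scatter). Compound 4 is therefore estimated at 5000 nM in this assay, with a range expected from 1500 nM to 30000 nM, and a real chance that only a limit is reported again.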

Compound 4, half-maximal inhibitory concentration: > 10000 nM
Compound 4 gave a limit, no number; the forecaster's own chance of this, stated with the estimate: 40%; middle value at least 2.0-fold (0.30 log units) away from the limit.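

Compound 3 and compound 4 both stop at a limit rather than a number, so no step can be read between them in this assay, because each sits at the same limit: the limit of > 10000 nM in this assay, at which 2 of the 4 values shown sit.

The compounds shown leave open whether ethyl in place of methoxy changes the read-out on the core of compound 3 at all, and whether any such change would compare with a 4.7-fold lower number from compound 1 to compound 2 (0.67 log units; beyond the scatter).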